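The compounds below may be only part of what the source reports. "The series", "measured", "known", "first", "only" and "open" are said of these compounds alone.

Compound 2 `CCOc1ccc(-c2cccc(C(=O)O)c2)cc1` gives 23% in an assay on COS-7 cells for inhibition of patatin-like phospholipase domain-containing protein 2 (Mus musculus), tested at 200 uM (a lower number here means less inhibition, a higher number more inhibition at the concentration tested (going by the name of the read-out)), the lowest of the two numbers in hand. Its nearest neighbour, compound 1 `CCOc1ccc(-c2cccc(S(=O)(=O)NC)c2)cc1`, gives 47% in this assay, and the step between them is a number 24 percentage points lower from compound 1 to compound 2 (beyond the scatter). Compound 3 `CCCCOC(=O)c1cccc(-c2ccc(OCC)cc2)c1` differs from compound 2 by butyl in place of hydrogen on an oxygen next to a carbonyl group. Going by the values given here, no measured step covers this change: the single step in hand swaps carboxy for methylsulfamoyl, and neither side of it carries butyl, so it shows only that the carboxy compound sits below the methylsulfamoyl one. The expectation for compound 3 in this assay therefore rests on the value of compound 2 alone, with wide uncertainty in either direction. The expected step is a number 17 percentage points higher from compound 2 to compound 3 (beyond the scatter). Compound 3 is estimated at 40%, between 15% and 65%.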

Compound 3, a percentage reported as inhibition, at one concentration (the size of the read-out at that concentration, not a potency): 61%
Compound 3: middle estimate off by 21 percentage points, on the low side, and the stated range covers the measured number.
By their numbers in this assay, from the lowest: compound 2; then compound 1; then compound 3.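

In this assay, putting butyl on the carboxy oxygen of compound 2 gives a number 38 percentage points higher from compound 2 to compound 3 (beyond the scatter) and so shows that this position responds to a change on that oxygen, not only to replacing the whole group. Butoxycarbonyl also compares well with methylsulfamoyl on the same aromatic carbon, with a number 14 percentage points higher from compound 1 to compound 3 (beyond the scatter) as the step, so a hydrogen on this oxygen is not required for inhibition at the concentration tested. Nothing measured in hand bears on the cause of either rise.

Going by these compounds, only butyl stands on this oxygen, so it remains open whether the rise tracks chain length or would appear with any ester; a methyl ester and a longer chain such as octyl would separate these. On these data alone, it is also open how an amide with the butyl chain on nitrogen would compare with the ester.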